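From Benzyloxy to 3,4-Dichlorophenyl: Estimating Compound 4

The compounds below may be only part of what the source reports. "The series", "measured", "known", "first", "only" and "open" are said of these compounds alone.

Of the compounds shown here, three built on one shared core have been measured in a functional assay on CCRF-CEM cells (Homo sapiens) for inhibition; a lower number here means that less compound is tolerated, a higher number that more compound is tolerated. Compound 1 `O=C1c2ccccc2N(Cc2ccc(Cl)cc2)S(=O)(=O)N1Cc1ccccc1` gives 19700 nM. Compound 2 `C#CCOCN1c2ccccc2C(=O)N(Cc2ccccc2)S1(=O)=O` gives 23000 nM, and compound 3 `O=C1c2ccccc2N(COCc2ccccc2)S(=O)(=O)N1Cc1ccccc1` gives 25000 nM. As the numbers stand, compound 3 holds the highest of the three, but its gap to compound 2 and its gap to compound 1 are both within the scatter, so the three compounds sit together rather than in any real order.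

Compound 4 `O=C1c2ccccc2N(Cc2ccc(Cl)c(Cl)c2)S(=O)(=O)N1Cc1ccccc1` has not yet been measured. Relative to compound 3 it carries 3,4-dichlorophenyl in place of benzyloxy on a saturated chain carbon bound to a sulfonamide nitrogen in a ring. The measured step that bears most directly on this change is a 1.3-fold higher number from compound 1 to compound 3 (0.10 log units; within the scatter), which exchanged benzyloxy for 4-chlorophenyl at the same place and stayed within the scatter. The steps of a 1.2-fold higher number from compound 1 to compound 2 (0.07 log units; within the scatter) and a 1.1-fold higher number from compound 2 to compound 3 (0.04 log units; within the scatter), which also vary this position, did the same. Among the measured compounds shown here, nothing among the measured compounds separates a ring bearing two chlorines from one bearing a single chlorine, so no step beyond the scatter is expected in either direction.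

Compound 4 is therefore estimated at 20000 nM, with a range from 9000 nM to 45000 nM. That estimate corresponds to an expected step of a 1.3-fold lower number from compound 3 to compound 4 (0.10 log units; within the scatter).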

Compound 4, half-maximal cytotoxic concentration: 16400 nM
The estimate for compound 4 lay 1.2-fold (0.09 log units) above the measured number; the measured number falls inside the stated range.
By their numbers in this assay, from the lowest: compounds 4, 1, 2 and 3 (each within the scatter of the next).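

In this assay, among the compounds shown here, the chloro in place of hydrogen on an aromatic carbon gives the first direct reading of a ring bearing two chlorines against one bearing a single chlorine, a 1.2-fold lower number from compound 1 to compound 4 (0.08 log units; within the scatter), and that step lies within the scatter. At this place, on a saturated chain carbon bound to a sulfonamide nitrogen in a ring, 3,4-dichlorophenyl also stays within the scatter of both groups with an oxygen in the chain, with a 1.5-fold lower number from compound 3 to compound 4 (0.18 log units; within the scatter) against benzyloxy and a 1.4-fold lower number from compound 2 to compound 4 (0.15 log units; within the scatter) against propargyloxy, so all four groups shown leave the number unresolved from one another. Nothing in hand accounts for how closely these four compounds sit together.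

Whether an amine or a carboxylic acid at this place would give a step beyond the scatter remains open, since every group shown here carries no net charge. The compounds also differ only at this one place, so what a change elsewhere on the shared core would do in this assay cannot be said from them.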